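The compounds below may be only part of what the source reports. "The series", "measured", "known", "first", "only" and "open" are said of these compounds alone.

Measured compounds and values:

- compound 1, `C=CC(=O)N1C(=O)CC(C)Sc2ccccc21`: 730000 nM
- compound 2, `C=CC(=O)N1C(=O)CC(c2ccc(Br)cc2)Sc2ccccc21`: 106000 nM
- compound 3, `C=CC(=O)N1C(=O)CC(c2ccccc2C(F)(F)F)Sc2ccccc21`: 84400 nM

In a functional assay on MOLT-4 cells (Homo sapiens) for cytotoxicity, read by CCK-8 assay, with a stated time of 24 h (a lower number here means a stronger inhibitor, a higher number a weaker inhibitor), compound 2 gives the second highest number of the three. Its nearest neighbour is compound 3, and the gap between them is within the scatter; its furthest is compound 1, which sits beyond the scatter above it. Going by the values given here, the one single-point step measured is a 6.9-fold lower number from compound 1 to compound 2 (0.84 log units; beyond the scatter), a modest step in the direction of a stronger inhibitor.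

Compound 4, `C=CC(=O)N1C(=O)CC(c2ccccc2)Sc2ccccc21`, is not yet measured. It differs from compound 2 in one place: hydrogen in place of bromo on an aromatic carbon. Among the compounds with values here, no measured step touches exactly this change, so what it will do rests only indirectly on the one step that is known. That step shows an aryl group on the saturated ring carbon gives a much lower number than methyl, and compound 4 keeps an aryl group there. Compound 4 is therefore expected to stay nearer compound 2 and compound 3 than compound 1, with a small upward shift, a 1.9-fold higher number from compound 2 to compound 4 (0.28 log units; within the scatter). The estimate for compound 4 in this assay is 200000 nM, within a range of 80000 nM to 500000 nM.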

Compound 4, half-maximal inhibitory concentration: 85900 nM
Beside the measured number, compound 4's estimate is 2.3-fold (0.37 log units) above it; low and high end bracket the measured number.
By their numbers in this assay, from the lowest: compounds 3, 4 and 2 (each within the scatter of the next); then compound 1.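

In this assay, taking the bromo off the 4-bromophenyl group (a 1.2-fold lower number from compound 2 to compound 4 (0.09 log units; within the scatter)) and taking the trifluoromethyl off the aryl group (a 1.0-fold higher number from compound 3 to compound 4 (0.01 log units; within the scatter)) both leave the number within the scatter, so neither substituent is needed for the level reached by these aryl compounds. The unsubstituted phenyl group alone already gives a step beyond the scatter from methyl on the saturated ring carbon (an 8.5-fold lower number from compound 1 to compound 4 (0.93 log units; beyond the scatter)), which places the gain seen so far with the aryl group itself rather than with anything attached to it. No measurement here offers a reason for this flat response to aryl substitution.

Whether any substituent on the phenyl ring can move the number remains open, as bromo and trifluoromethyl are the only two shown, and an amine or a carboxylic acid there could read differently. A longer chain in place of the methyl would show whether a carbon chain can approach the aryl level.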